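The compounds below may be only part of what the source reports. "The series", "measured", "known", "first", "only" and "open" are said of these compounds alone.

Measured so far:
- Compound 1, `COc1cc2c(Oc3ccc(NC(=O)c4nn(-c5ccccc5)c(=O)c5ccccc45)cc3F)ccnc2cc1OCCCN1CCCC1`: 480 nM
- Compound 2, `COc1cc2c(Oc3ccc(NC(=O)c4nn(-c5ccccc5F)c(=O)c5ccccc45)cc3F)ccnc2cc1OCCCN1CCCC1`: 230 nM
- Compound 3, `COc1cc2c(Oc3ccc(NC(=O)c4nn(-c5ccc(Br)cc5)c(=O)c5ccccc45)cc3F)ccnc2cc1OCCCN1CCCC1`: 180 nM

All three share one core and differ only in the phenyl ring attached to the aromatic nitrogen. In a functional assay on NCI-H460 cells (Homo sapiens) for cytotoxicity, read by MTT assay, with a stated time of 72 h (a lower number here means a stronger inhibitor, a higher number a weaker inhibitor), compound 3 and compound 2 sit together at the low end of the numbers, while compound 1 stands higher than both. The two steps that lead there are a 2.1-fold lower number from compound 1 to compound 2 (0.32 log units; beyond the scatter) and a 2.7-fold lower number from compound 1 to compound 3 (0.43 log units; beyond the scatter), each a modest gain from putting a halogen on that phenyl ring; the pair of halogen compounds themselves differ by a 1.3-fold lower number from compound 2 to compound 3 (0.11 log units; within the scatter), which is within scatter.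

Compound 4, `COc1cc2c(Oc3ccc(NC(=O)c4nn(-c5ccc([N+](=O)[O-])cc5)c(=O)c5ccccc45)cc3F)ccnc2cc1OCCCN1CCCC1`, carries the change (nitro in place of bromo on an aromatic carbon). Within the data shown here, no measured step swaps a halogen for a nitro group here, so the closest guide is that the unsubstituted ring in compound 1 gave a weaker result than either halogen ring. A substituted ring is therefore expected to stay near compound 3, with a step of a 1.2-fold higher number from compound 3 to compound 4 (0.09 log units; within the scatter). Compound 4 is estimated at 220 nM, within 80 nM to 600 nM.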

Compound 4, half-maximal inhibitory concentration: 1240 nM
The estimate for compound 4 lay 5.6-fold (0.75 log units) below the measured number, outside the stated range (above it).
By their numbers in this assay, from the lowest: compounds 3 and 2 (each within the scatter of the next); then compound 1; then compound 4.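

In this assay a substituent on this phenyl ring does not always lower the number: the nitro group gives a 2.6-fold higher number from compound 1 to compound 4 (0.41 log units; beyond the scatter) and so moves opposite to the bromo and fluoro groups, both of which lowered it from the unsubstituted ring. The position is therefore sensitive to which group it carries, as replacing bromo with nitro on the same aromatic carbon gives a 6.9-fold higher number from compound 3 to compound 4 (0.84 log units; beyond the scatter) and the change of the whole ring from 2-fluorophenyl to 4-nitrophenyl gives a 5.4-fold higher number from compound 2 to compound 4 (0.73 log units; beyond the scatter) in the same direction. Nothing measured here explains why nitro and bromo part ways.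

From the compounds shown here alone, whether nitro is a lone case remains open, since a single compound cannot define a trend. An amine, a nitrile or a methoxy group on that same aromatic carbon would show whether the number rises only with nitro or with other groups too.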